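A few compounds are considered here, and "the series" means these few. Any claim that something is new, unique, unknown or untested is made for them only; others in the source may bear on it.

Of the compounds shown here, three built on one shared core have been measured in a functional assay on KBVIN cells (Homo sapiens) for antiproliferative activity, read by sulforhodamine B assay, with a stated time of 3 days; a higher number here means that more compound is needed for the effect, a lower number that less compound is needed. Compound 1 `CCCCc1ccc(-c2cc(=O)c3c(o2)C(CC)(CC)C(=O)C(CC)=C3O)cc1` gives 37 uM, compound 2 `CCC1=C(O)c2c(oc(-c3ccc(OC)cc3)cc2=O)C(CC)(CC)C1=O` gives 0.68 uM, and compound 3 `CCC1=C(O)c2c(oc(-c3ccc(CBr)cc3)cc2=O)C(CC)(CC)C1=O` gives 27.9 uM. Compound 3 thus stands second highest of the three numbers, close to compound 1 and far from compound 2. The move from compound 3 to compound 4 `CCC1=C(O)c2c(oc(-c3ccc(C)c(Cl)c3)cc2=O)C(CC)(CC)C1=O` is 3-chloro-4-methylphenyl in place of 4-(bromomethyl)phenyl on an aromatic carbon. Among the measured compounds shown here, two measured steps bear on this change: a 41-fold higher number from compound 2 to compound 3 (1.61 log units; beyond the scatter), and a 54-fold lower number from compound 1 to compound 2 (1.74 log units; beyond the scatter). In both, the methoxy-bearing compound 2 stands far apart, while compound 1 with butyl and compound 3 with bromomethyl sit together within the scatter. Compound 4 carries neither a methoxy nor anything resembling it, so no step beyond the scatter is expected from compound 3. Compound 4 is therefore expected to give about 20 uM, with a range from 5 uM to 60 uM. The expected step of a 1.4-fold lower number from compound 3 to compound 4 (0.14 log units; within the scatter) is accordingly small.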

Compound 4, concentration for half-maximal effect: 2.15 uM
The estimate for compound 4 lay 9.3-fold (0.97 log units) above the measured number; measured number outside the range, below it.
By their numbers in this assay, from the lowest: compound 2; then compound 4; then compounds 3 and 1 (each within the scatter of the next).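

In this assay the swap of 4-(bromomethyl)phenyl for 3-chloro-4-methylphenyl brings a 13-fold lower number from compound 3 to compound 4 (1.11 log units; beyond the scatter), so at this position a low number is not confined to the methoxy-bearing compound 2. Even so, the new group does not fully match 4-methoxyphenyl, with a 3.2-fold higher number from compound 2 to compound 4 (0.50 log units; beyond the scatter), and compound 2 keeps the lowest number of the four. The leaving and entering groups have the same counts of heavy atoms, hydrogen-bond donors and acceptors, and neither carries a net charge, yet the numbers lie far apart, and nothing measured here accounts for the difference.

Going by these compounds, it remains open whether the chlorine or the methyl attached directly to the ring matters more, as compound 4 brings both at once; a plain 3-chlorophenyl or 4-methylphenyl group would separate them. On these data alone, how an amine or a carboxylic acid on this phenyl ring would behave also remains open.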